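A few compounds are considered here, and "the series" means these few. Any claim that something is new, unique, unknown or untested is made for them only; others in the source may bear on it.

Measured compounds:
- compound 1 `COc1ccc(CN(C(=O)Nc2ccc(Cl)c(C(F)(F)F)c2)n2cnnc2)cc1OC`: in a functional assay on DU-145 cells (Homo sapiens) for cytotoxicity, read by MTT assay, with a stated time of 48 h (a higher number here means a weaker inhibitor, a lower number a stronger inhibitor), compound 1 reaches only the assay limit, > 50000 nM, not a number.
- compound 2 `N#Cc1ccc(CN(C(=O)Nc2cc(C(F)(F)F)cc(C(F)(F)F)c2)n2cnnc2)cc1`: compound 2 gives 11800 nM.
- compound 3 `COc1ccc(CN(C(=O)Nc2ccc(F)c(Cl)c2)n2cnnc2)cc1OC`: compound 3 gives 23300 nM.

Among the two numbers recorded, compound 2 carries the lower one, but its nearest neighbour, compound 3, lies within the usual scatter of it, so no ordering between compound 2 and compound 3 can be claimed. Compound 1 stands apart as a limit only (the limit of > 50000 nM in this assay, at which 1 of the 3 values shown sits).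

Compound 4 `COc1ccc(CN(C(=O)Nc2cc(C(F)(F)F)cc(C(F)(F)F)c2)n2cnnc2)cc1OC` is the bis-trifluoromethyl urea of compound 2 carrying a different benzyl group: 3,4-dimethoxyphenyl in place of 4-cyanophenyl on a saturated chain carbon bound to an amide-type nitrogen. Within the data shown here, no pair of measured compounds shows this change on its own. The two compounds that already carry 3,4-dimethoxyphenyl, compound 1 with > 50000 nM and compound 3 with 23300 nM, both give the weaker readings in this assay, though their aryl ureas differ from that of compound 2 as well. On that basis compound 4 is expected to read somewhat weaker than compound 2, by a step of a 2.1-fold higher number from compound 2 to compound 4 (0.33 log units; beyond the scatter), possibly beyond the scatter. The estimate for compound 4 is 25000 nM, within a range from 8000 nM to 60000 nM.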

Compound 4, half-maximal inhibitory concentration: 26400 nM
Compound 4: middle estimate off by 1.1-fold (0.02 log units), on the low side; the range from low to high includes it.
By their numbers in this assay, from the lowest: compounds 2, 3 and 4 (each within the scatter of the next, the first and the last beyond it). At a limit, above all of these: compound 1.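

In this assay, among these compounds, the exchange of 4-cyanophenyl for 3,4-dimethoxyphenyl on a saturated chain carbon bound to an amide-type nitrogen, with the bis-trifluoromethyl urea unchanged, gives a 2.2-fold higher number from compound 2 to compound 4 (0.35 log units; beyond the scatter) and is the first reading of this change on its own. The earlier compounds shown here could not separate the benzyl group from the aryl urea, whereas this modest step shows that the benzyl position alone moves the reading beyond the scatter. Compound 4 still gives a measured value of 26400 nM and not a limit, and nothing shown gives a cause for the step.

As far as these compounds go, whether the step keeps its size with another aryl urea remains open, as 4-cyanobenzyl appears here with one urea only. From the compounds shown here alone, how a benzyl group bearing an amine or a carboxylic acid would read also remains open.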